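The compounds below may be only part of what the source reports. "The series", "measured", "known", "first", "only" and "open" are said of these compounds alone.

Compound 1 `Cc1nc(C(NC(=O)C(=O)Nc2ccc(Cl)cc2)C2CCNCC2)sc1CO`: > 81000 nM, a limit.
Compound 2 `Cc1nc(C(NC(=O)C(=O)Nc2ccc(Cl)cc2)C2CCCN2)sc1CO`: 45000 nM.
Compound 3 `Cc1nc(C(NC(=O)C(=O)Nc2ccc(F)c(Cl)c2)C2CCCCN2)sc1CO`: > 77800 nM, a limit.

In an ADME assay on MT2 cells (Homo sapiens) for cytotoxicity, read by XTT assay, with a stated time of 4 days (on this read-out higher numbers stand for lower toxicity in this test and lower numbers for higher toxicity in this test), compound 3 has no exact number, only the limit > 77800 nM. Compound 4 `Cc1nc(C(NC(=O)C(=O)Nc2ccc(F)cc2F)C2CCCCN2)sc1CO` differs from it in one place: 2,4-difluorophenyl in place of 3-chloro-4-fluorophenyl on an amide-type nitrogen. In words, 2,4-difluorophenyl takes the place of 3-chloro-4-fluorophenyl on an amide-type nitrogen. Within the data shown here, no measured step covers this change. The only one available is an at least 1.8-fold lower number from compound 1 to compound 2 (0.25 log units; that floor lies within the scatter), which lies in another part of the molecule, so it bears only weakly here. No step beyond the scatter is therefore expected in this assay. The expected step is an at least 1.0-fold lower number from compound 3 to compound 4 (0.01 log units; that floor lies within the scatter). Compound 4 is expected near 75000 nM, with an estimated range from 38000 nM to 110000 nM.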

Compound 4, half-maximal cytotoxic concentration: > 110000 nM
Compound 4: a limit, no number; the forecaster's own chance of this, stated with the estimate: 65%; at least 1.4-fold (0.16 log units) between middle value and limit.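

Compound 3 and compound 4 each carry only a limit, not a number, and the step between them cannot be read. The compounds shown leave open whether 2,4-difluorophenyl and 3-chloro-4-fluorophenyl on the amide-type nitrogen differ at all in this assay.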